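The source may report more compounds than this note shows. Statements on the series, on what has been measured and on what is new or still open speak of the compounds shown alone.

Measured so far in an assay on isolated protein with retinoic acid receptor gamma (Homo sapiens) as the target; on this read-out higher numbers stand for larger maximal responses and lower numbers for smaller maximal responses:
compound 1 `CC1(C)CCC(C)(C)c2cc(C(=O)c3ccc4cc(C(=O)O)ccc4c3)c(O)cc21`: 70%
compound 2 `Cc1cc2c(cc1C(=O)c1ccc3cc(C(=O)O)ccc3c1)C(C)(C)CCC2(C)C`: 58%
compound 3 `CC1(C)CCC(C)(C)c2cc(C(=O)c3ccc4cc(C(=O)O)ccc4c3)c(F)cc21`: 70%

Compound 3 stands level with compound 1 at the digits given in this assay, the two together the highest of the three numbers; against compound 2 the step is a number 12 percentage points higher from compound 2 to compound 3 (beyond the scatter). Compound 4 `COc1cc2c(cc1C(=O)c1ccc3cc(C(=O)O)ccc3c1)C(C)(C)CCC2(C)C` differs from compound 3 in one place: methoxy in place of fluoro on an aromatic carbon. Among the compounds with values here, the steps that bear on this are the two at the same aromatic carbon: no change at the digits printed from compound 1 to compound 3 (within the scatter) and a number 12 percentage points lower from compound 1 to compound 2 (beyond the scatter). From the compounds shown here alone, a carbon-bearing group at that position, in compound 2, sits lower than the fluoro of compound 3 and the hydroxy of compound 1; methoxy is untested here, so a modest drop or no change beyond the scatter is expected. Compound 4 is estimated at 64% (range 50% to 76%), a step of a number 6 percentage points lower from compound 3 to compound 4 (within the scatter) expected.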

Compound 4, largest response reached (reported as maximum), in percent of the reference or control that the assay uses: 53%
Beside the measured number, compound 4's estimate is 11 percentage points above it, and the stated range covers the measured number.
By their numbers in this assay, from the lowest: compounds 4 and 2 (each within the scatter of the next); then compounds 1 and 3 (each within the scatter of the next).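

In this assay, methyl in place of the hydrogen on the hydroxy oxygen gives a number 17 percentage points lower from compound 1 to compound 4 (beyond the scatter) and methoxy in place of fluoro gives a number 17 percentage points lower from compound 3 to compound 4 (beyond the scatter) in the same series. With methoxy in place of methyl there is a number 5 percentage points lower from compound 2 to compound 4 (within the scatter) and so the lower level at this aromatic carbon, earlier seen with methyl alone, now holds for two carbon-bearing groups, while hydroxy and fluoro stay at the upper level. Nothing available here explains this difference. From the compounds shown here alone, whether ethoxy, a longer chain, an amine or a chloro group at this carbon would sit with methoxy and methyl or with hydroxy and fluoro remains open.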